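Chloro on a second core, where limits rule

A few compounds are considered here, and "the series" means these few. Any claim that something is new, unique, unknown or untested is made for them only; others in the source may bear on it.

Compound 1 `O=c1cc(CSc2nc3ccccc3s2)oc2ccccc12`: > 25000 nM
Compound 2 `O=c1cc(CSc2nc3ccccc3s2)oc2ccc(Cl)cc12`: > 25000 nM
Compound 3 `Nc1nnc(SCc2cc(=O)c3ccccc3o2)s1`: > 25000 nM

Each of these values is a limit of a functional assay on LM7 cells (Homo sapiens) for cytotoxicity, read by MTT assay, with a stated time of 72 h (a higher number here means a weaker inhibitor, a lower number a stronger inhibitor), and not a number. The change from compound 1 to compound 2 is chloro in place of hydrogen on an aromatic carbon. The step that the two limits leave unreadable from compound 1 to compound 2, as every value sits at the limit of > 25000 nM in this assay, at which 3 of the 3 values shown sit. How the core of compound 3 differs from the core of compound 1 is not broken down here. Compound 4 `Nc1nnc(SCc2cc(=O)c3cc(Cl)ccc3o2)s1` repeats the same change on the core of compound 3: chloro in place of hydrogen on an aromatic carbon. In this assay compound 3 gives only a limit, > 25000 nM. The earlier step gives no readable size, so compound 4 is expected to stay at the limit as well, with an expected step that the limit leaves unreadable from compound 3 to compound 4. Compound 4 is thus estimated at 35000 nM, between 8000 nM and 150000 nM.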

Compound 4, half-maximal inhibitory concentration: > 25000 nM
Compound 4: a limit, no number; the forecaster's own chance of this, stated with the estimate: 85%; the middle value does not contradict the limit.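

No step can be read from compound 3 to compound 4, as both values are limits and not numbers: the limit of > 25000 nM in this assay, at which 4 of the 4 values shown sit.

The compounds shown leave open whether chloro in place of hydrogen on an aromatic carbon has any effect on either core.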